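Replacing a side group on a weakly active compound

The compounds below may be only part of what the source reports. "The series", "measured", "known", "first", "only" and "open" are said of these compounds alone.

Measured in a functional assay on L1210 cells (Mus musculus) for inhibition; on this read-out lower numbers stand for stronger inhibition and higher numbers for weaker inhibition:
Compound 1 `C#CCN(Cc1ccc2nc(NCC(=O)O)nc(O)c2c1)c1ccc(C(=O)NC(CCC(=O)O)C(=O)O)cc1`: > 100000 nM (a limit of the assay, not a number)
Compound 2 `COc1nc(O)c2cc(CNc3ccc(C(=O)NC(CCC(=O)O)C(=O)O)cc3)ccc2n1`: 6400 nM

Among the compounds with values here, only two compounds have been measured here, so there is little to build on. Compound 1 has no exact number, and its reading is only a limit: the limit of > 100000 nM in this assay, at which 1 of the 2 values shown sits. Its true value is therefore unknown, and it sits at the weak end of the numbers shown.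

The next compound, compound 3 `C#CCN(Cc1ccc2nc(Oc3ccccc3)nc(O)c2c1)c1ccc(C(=O)NC(CCC(=O)O)C(=O)O)cc1`, keeps the rest of compound 1 and changes one group. Phenoxy stands in place of (carboxymethyl)amino on an aromatic carbon, between two ring nitrogen atoms: phenoxy in place of (carboxymethyl)amino on an aromatic carbon.

Within the data shown here, no measured pair isolates this change, so any expectation rests on thin ground. Compound 2 also lacks the (carboxymethyl)amino group and gives 6400 nM, but it differs from compound 1 elsewhere too, which makes it only a loose guide. The estimated change is an at least 6.6-fold lower number from compound 1 to compound 3 (0.82 log units; beyond the scatter), in the direction of stronger inhibition. For compound 3 the expected value is 15000 nM, with an estimated range of 3000 nM to 80000 nM.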

Compound 3, half-maximal inhibitory concentration: > 100000 nM
Compound 3: no number, only a limit (the forecaster's own chance of this, stated with the estimate: 25%); at least 6.6-fold (0.82 log units) between middle value and limit.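

In this assay compound 3 gives > 100000 nM as its reading, a limit of the assay and not a number. Compound 1 also has only a limit, so no step can be read between compound 1 and compound 3: the limit of > 100000 nM in this assay, at which 2 of the 3 values shown sit. The compounds shown leave open whether phenoxy in place of (carboxymethyl)amino changes inhibition at all, and in which direction.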